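Fluoro to Iodo on a Thioether Nucleoside Series

The source may report more compounds than this note shows. Statements on the series, on what has been measured and on what is new or still open speak of the compounds shown alone.

Measured so far in an assay on isolated protein for binding affinity to Equilibrative nucleoside transporter 1 (Homo sapiens); on this read-out higher numbers stand for weaker inhibition and lower numbers for stronger inhibition:
compound 1 `OC[C@H]1O[C@@H](n2cnc3c(CSc4ccccc4F)ncnc32)[C@H](O)[C@@H]1O` gives 355 nM
compound 2 `OC[C@H]1O[C@@H](n2cnc3c(CSc4ccccc4I)ncnc32)[C@H](O)[C@@H]1O` gives 282 nM
compound 3 `OC[C@H]1O[C@@H](n2cnc3c(CSc4ccc(F)cc4)ncnc32)[C@H](O)[C@@H]1O` gives 158 nM

Compound 3 differs from compound 1 by 4-fluorophenyl in place of 2-fluorophenyl on a sulfur; the step is a 2.2-fold lower number from compound 1 to compound 3 (0.35 log units; beyond the scatter). Compound 2 differs from compound 1 by iodo in place of fluoro on an aromatic carbon, a step of a 1.3-fold lower number from compound 1 to compound 2 (0.10 log units; within the scatter). Compound 4 `OC[C@H]1O[C@@H](n2cnc3c(CSc4ccc(I)cc4)ncnc32)[C@H](O)[C@@H]1O` is not yet measured and differs from compound 3 by iodo in place of fluoro on an aromatic carbon. Among the measured compounds shown here, this is the same kind of change as the one from compound 1 to compound 2, but not the same: there the iodo sits ortho to a large group, here para to a large group. For compound 4 the expected step in this assay is a 1.1-fold lower number from compound 3 to compound 4 (0.02 log units; within the scatter), resting on compound 1 and compound 2 because a 1.3-fold lower number from compound 1 to compound 2 (0.10 log units; within the scatter) was small. Compound 4 is therefore estimated at 150 nM, with a likely range from 70 nM to 350 nM.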

Compound 4, half-maximal inhibitory concentration: 69.2 nM
Beside the measured number, compound 4's estimate is 2.2-fold (0.34 log units) above it, outside the stated range (below it).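

In this assay, iodo in place of fluoro gives a 2.3-fold lower number from compound 3 to compound 4 (0.36 log units; beyond the scatter), and the larger changes to the 4-iodophenyl group give a 4.1-fold lower number from compound 2 to compound 4 (0.61 log units; beyond the scatter) and a 5.1-fold lower number from compound 1 to compound 4 (0.71 log units; beyond the scatter). Although only the new swap lies beyond the scatter, the two swaps do not differ by more than the scatter of such steps allows, so the change carries across these two cores as far as can be told: the same change on two cores in this assay, a 1.3-fold lower number (0.10 log units; within the scatter) from compound 1 to compound 2 and a 2.3-fold lower number (0.36 log units; beyond the scatter) from compound 3 to compound 4, 1.8-fold (0.26 log units) apart, within the scatter of two such steps. Two pairs cannot show that the step is truly the same size on both cores, and they say nothing about any third core.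

On these data alone, whether chloro or bromo in place of iodo would give steps of similar size stays open. So does how an amine or a carboxylic acid on the same ring would read.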